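A few compounds are considered here, and "the series" means these few. Any claim that something is new, unique, unknown or untested is made for them only; others in the source may bear on it.

In a functional assay on HCT-116 cells (Homo sapiens) for cytotoxicity, read by sulforhodamine B assay, with a stated time of 24 h (on this read-out higher numbers stand for weaker inhibition and lower numbers for stronger inhibition), compound 3 (`O=C1Nc2ccc(S(=O)(=O)N3CCOCC3)cc2/C1=N/Nc1ccccc1`) gives 10500 nM and stands lowest of the three measured compounds, below compound 2 (`O=C1Nc2ccc(S(=O)(=O)N3CCOCC3)cc2/C1=N/NC(=O)c1ccccc1`) at 28900 nM and compound 1 (`N/N=C1\C(=O)Nc2ccc(S(=O)(=O)N3CCOCC3)cc21`) at 36300 nM on this scale. Compound 4 (`O=C1Nc2ccc(S(=O)(=O)N3CCOCC3)cc2/C1=N/c1ccc(Cl)cc1`) differs from compound 3 as follows (4-chlorophenyl in place of anilino on a double-bonded nitrogen): 4-chlorophenyl in place of anilino on a double-bonded nitrogen. The nearest evidence comes from changes on an amine nitrogen: a 1.3-fold lower number from compound 1 to compound 2 (0.10 log units; within the scatter) stays within the scatter, while a 3.5-fold lower number from compound 1 to compound 3 (0.54 log units; beyond the scatter) and a 2.8-fold lower number from compound 2 to compound 3 (0.44 log units; beyond the scatter) are modest. None of these steps is large, and none exchanges a group directly on the double-bonded nitrogen. No change beyond the scatter is therefore expected in either direction, with an estimated 1.2-fold lower number from compound 3 to compound 4 (0.07 log units; within the scatter) in this assay as the likely outcome. Compound 4 is expected to give about 9000 nM (estimated range 3000 nM to 30000 nM).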

Compound 4, half-maximal inhibitory concentration: 24300 nM
Beside the measured number, compound 4's estimate is 2.7-fold (0.43 log units) below it; measured number inside the range.
By their numbers in this assay, from the lowest: compound 3; then compounds 4, 2 and 1 (each within the scatter of the next).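

On the double-bonded nitrogen, replacing anilino with 4-chlorophenyl gives a 2.3-fold higher number from compound 3 to compound 4 (0.36 log units; beyond the scatter) in this assay, so this position responds to the exchange of a whole group. Meanwhile, a 1.2-fold lower number from compound 2 to compound 4 (0.08 log units; within the scatter) and a 1.5-fold lower number from compound 1 to compound 4 (0.17 log units; within the scatter) both stay within the scatter, which leaves compound 3 alone apart from the other three. No measurement here explains this difference.

Going by these compounds, the exchange removes the linking nitrogen of anilino and adds chlorine together, so their separate contributions remain open; 4-chloroanilino or plain phenyl on that nitrogen would separate them.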